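The source may report more compounds than this note shows. Statements on the series, on what has been measured and on what is new or still open speak of the compounds shown alone.

In a functional assay on the whole organism with Canis familiaris (Canis lupus familiaris) as the target (on this read-out higher numbers stand for an effect only at larger amounts of compound and lower numbers for an effect already at smaller amounts), compound 1 `c1ccc(-c2nc3cc[nH]cc-3n2)cc1` gives 2.5 mg/kg, compound 2 `CSc1ccc(-c2nc3cc[nH]cc-3n2)cc1` gives 4 mg/kg and compound 3 `COc1ccc(-c2nc3cc[nH]cc-3n2)cc1` gives 1.7 mg/kg. The numbers do not separate compound 3 from compound 1, with a 1.5-fold lower number from compound 1 to compound 3 (0.17 log units; within the scatter). It stands clear only of compound 2, with a 2.4-fold lower number from compound 2 to compound 3 (0.37 log units; beyond the scatter).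

Compound 4 `COc1ccc(-c2nc3cc[nH]cc-3n2)c(OCCSC)c1` keeps the methoxy group of compound 3 and carries 2-(methylsulfanyl)ethoxy in place of hydrogen on an aromatic carbon.

Two measured steps also replace hydrogen on an aromatic carbon: a 1.5-fold lower number from compound 1 to compound 3 (0.17 log units; within the scatter) and a 1.6-fold higher number from compound 1 to compound 2 (0.20 log units; within the scatter). Both are small, but neither fills this carbon or adds a chain of this kind, so they offer only weak guidance. The new group, like the methoxy group, is attached through oxygen, and the methoxy step in compound 3 (a 1.5-fold lower number from compound 1 to compound 3 (0.17 log units; within the scatter)) leans towards a lower number. On that slender basis, a modest move towards a lower number in this assay is expected, although no change beyond the scatter remains possible. The expected step is a 1.7-fold lower number from compound 3 to compound 4 (0.23 log units; within the scatter). For compound 4, the estimated value is 1 mg/kg, with an expected range from 0.3 mg/kg to 3 mg/kg.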

Compound 4, dose for half-maximal effect: 1.1 mg/kg
Estimate against measurement, compound 4: 1.1-fold (0.04 log units) below; measured number inside the range.
By their numbers in this assay, from the lowest: compounds 4, 3, 1 and 2 (each within the scatter of the next, the first and the last beyond it).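

The replacement of hydrogen by 2-(methylsulfanyl)ethoxy gives a 1.5-fold lower number from compound 3 to compound 4 (0.19 log units; within the scatter) in this assay. Within the data shown here, compounds 1, 2 and 3 all carry hydrogen on this aromatic carbon, ortho to a group of 9 heavy atoms and meta to a methoxy group, so compound 4 gives the first reading of a substituent there, and it shows that this carbon can bear a chain of this size with no change that stands clear of the scatter. Nothing available bears on the reason for this result.

With a single substituent at this carbon, the compounds shown cannot tell whether the chain as a whole, its ether oxygen or its sulfur atom shapes the read-out, and a step that stays within the scatter could hide a small effect in either direction. Going by these compounds, it also remains open whether a plain methoxy group, a longer chain, or a chain ending in an amine or a carboxylic acid would be accommodated at this carbon in the same way.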